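A few compounds are considered here, and "the series" means these few. Any claim that something is new, unique, unknown or untested is made for them only; others in the source may bear on it.

Compound 1 `C[Se]c1nc(N)c2ccccc2n1` gives 27600 nM in a functional assay on HT-29 cells (Homo sapiens) for cytotoxicity, read by MTT assay, with a stated time of 72 h; on this read-out lower numbers stand for stronger inhibition of growth and higher numbers for weaker inhibition of growth. Compound 2 `CCCCC[Se]c1nc(NCc2ccc(SC)cc2)c2ccccc2n1` gives 83600 nM. Compound 3 `CSc1ccc(CNc2nc([SeH])nc3ccccc23)cc1` gives 42900 nM.

Among these three, compound 2 has the highest number in this assay, that is, the weakest inhibition of growth. Among the measured compounds shown here, its gap to compound 3 is small: the one measured step between two compounds that differ in a single place is a 1.9-fold lower number from compound 2 to compound 3 (0.29 log units; within the scatter), produced by hydrogen in place of pentyl on a selenium. Compound 1 differs from compound 2 in more than one place, and its lower number lies beyond the scatter.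

Compound 4 `CCCCC[Se]c1nc(NCc2ccccc2)c2ccccc2n1` departs from compound 2 by hydrogen in place of methylsulfanyl on an aromatic carbon, on a six-membered aromatic ring of carbon only, para to a large group. For the measured compounds named here, no measured step touches that ring; the only measured step concerns the selenium chain and stayed within the scatter. Without any comparison bearing on this change, the expectation is no step beyond the scatter, a 1.2-fold lower number from compound 2 to compound 4 (0.08 log units; within the scatter). Compound 4 is therefore estimated at 70000 nM, with a range from 30000 nM to 160000 nM.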

Compound 4, concentration for 50% growth inhibition: 72700 nM
Compound 4: middle estimate off by 1.0-fold (0.02 log units), on the low side; measured number inside the range.
By their numbers in this assay, from the lowest: compounds 1, 3, 4 and 2 (each within the scatter of the next, the first and the last beyond it).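

In this assay, the change from 4-(methylsulfanyl)phenyl to phenyl gives a 1.1-fold lower number from compound 2 to compound 4 (0.06 log units; within the scatter). Among the compounds shown here, this is the first single-place comparison on the aromatic ring, since the earlier step concerned only the chain on selenium. It shows that, with the pentyl chain on selenium in place, the methylsulfanyl group para to a large group can be replaced by hydrogen without a step beyond the scatter, though nothing available explains this result.

The compounds shown leave open whether a different group at this place, such as a methoxy group, an amine or a carboxylic acid, would give a step beyond the scatter. They also leave open whether the ring change would stay this small with hydrogen, rather than pentyl, on the selenium.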